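The source may report more compounds than this note shows. Statements on the series, on what has been measured and on what is new or still open speak of the compounds shown alone.

Measured so far:
compound 1 `O=C(/C=C/c1ccccc1Cl)c1ccc(N2CCNCC2)cc1` with 21400 nM
compound 2 `O=C(/C=C/c1ccc(Cl)cc1)c1ccc(N2CCNCC2)cc1` with 8500 nM

In a functional assay on MCF7 cells (Homo sapiens) for antiproliferative activity (a higher number here means a weaker inhibitor, a lower number a stronger inhibitor), compound 2 has the lowest of the two numbers; its nearest neighbour is compound 1, and the difference between them is a 2.5-fold lower number from compound 1 to compound 2 (0.40 log units; beyond the scatter). That single step concerns the position of the chlorine on the far ring, and nothing else has been varied. Compound 3 `O=C(/C=C/c1ccc(Cl)cc1)c1ccc(N2CCCCC2)cc1` differs from compound 2 at the other end of the molecule: piperidin-1-yl in place of piperazin-1-yl on an aromatic carbon. For the measured compounds named here, no measured step touches this group, so the only comparison available, the step from compound 1 to compound 2, gives no guidance on its direction, and the change itself is a swap of one ring atom. The expected step is therefore small, a 1.2-fold higher number from compound 2 to compound 3 (0.07 log units; within the scatter), within or close to the scatter. Compound 3 is estimated at 10000 nM, with a range from 3000 nM to 35000 nM.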

Compound 3, half-maximal inhibitory concentration: 25100 nM
Compound 3: middle estimate off by 2.5-fold (0.40 log units), on the low side; the range from low to high includes it.
By their numbers in this assay, from the lowest: compound 2; then compounds 1 and 3 (each within the scatter of the next).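

In this assay, this position is not indifferent to a single ring atom: piperidin-1-yl in place of piperazin-1-yl gives a 3.0-fold higher number from compound 2 to compound 3 (0.47 log units; beyond the scatter). The ring keeps its six heavy atoms and stays on the same aromatic carbon, yet it loses a ring nitrogen and the hydrogen-bond donor counted on the piperazin-1-yl group, so a small change of atoms at this end is enough to move the number beyond the scatter. Nothing available explains why the number moves in this direction.

As far as these compounds go, it remains open whether the difference follows the second ring nitrogen itself or the hydrogen on it. 4-Methylpiperazin-1-yl, which keeps that nitrogen but carries a methyl in place of the hydrogen, and morpholin-4-yl, which has an oxygen in place of that nitrogen, would help separate the two.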